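The source may report more compounds than this note shows. Statements on the series, on what has been measured and on what is new or still open speak of the compounds shown alone.

Compound 3 `CC(C)n1ncc2c(C(=O)Nc3cccc(F)c3F)cc(-c3cccs3)nc21` gives 75000 nM in an ADME assay on LLC-MK2 cells (Macaca mulatta) for cytotoxicity, read by spectrophotometry and crystal violet staining, with a stated time of 4 days; a lower number here means that less compound is tolerated, a higher number that more compound is tolerated. Among the compounds with values here, that is the higher of the two true numbers so far, and compound 2 `CC(C)n1ncc2c(C(=O)Nc3cccnc3)cc(-c3ccsc3)nc21` gives 37000 nM, a gap just beyond the scatter. Compound 1 `CC(C)n1ncc2c(C(=O)Nc3ccc(F)cc3F)cc(-c3cccs3)nc21` gives > 200000 nM, which is a limit of the assay and not a number.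

The next structure is compound 4 `CC(C)n1ncc2c(C(=O)Nc3cccnc3)cc(-c3cccs3)nc21`, where pyridin-3-yl stands in place of 2,3-difluorophenyl on an amide-type nitrogen: pyridin-3-yl in place of 2,3-difluorophenyl on an amide-type nitrogen. Two measurements bear on this change, neither of them directly. Within the data shown here, the only measured step, an at least 2.6-fold lower number from compound 1 to compound 3 (0.42 log units; beyond the scatter), swaps one difluorophenyl group for another, so it shows that this assay responds to changes at this amide-type nitrogen but says nothing about a pyridin-3-yl group. The closer guide is compound 2 at 37000 nM, which carries the same pyridin-3-yl on an amide-type nitrogen but is not identical to compound 4 elsewhere in the structure. Compound 4 is therefore expected to move from the number of compound 3 toward that of compound 2. The expected change is small: a 1.5-fold lower number from compound 3 to compound 4 (0.18 log units; within the scatter). For compound 4 the estimated value is 50000 nM, with an expected range of 22000 nM to 130000 nM.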

Compound 4, half-maximal cytotoxic concentration: > 200000 nM
Compound 4 ended at the assay's limit; the forecaster's own chance of this, stated with the estimate: 10%; middle value at least 4.0-fold (0.60 log units) from the limit.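

The pyridin-3-yl group on the amide-type nitrogen does not by itself lower the number in this assay, since replacing 2,3-difluorophenyl with it gives an at least 2.6-fold higher number from compound 3 to compound 4 (0.42 log units; beyond the scatter) in this series. Compound 2 carries the same pyridin-3-yl group, yet thiophen-2-yl in place of thiophen-3-yl on an aromatic carbon gives an at least 5.4-fold higher number from compound 2 to compound 4 (0.73 log units; beyond the scatter) here, so this second site also moves the number, and the value of compound 2 cannot be credited to the pyridin-3-yl group alone. On these data alone, the step between compound 1 and compound 4 cannot be read, and the true numbers of both remain unknown, as each stands only as a limit: the limit of > 200000 nM in this assay, at which 2 of the 4 values shown sit.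

The compounds shown leave open whether the thiophen-2-yl group keeps the number at that limit with other groups on the amide-type nitrogen, such as a piperidine ring, a short alkyl chain or a phenyl ring carrying a carboxylic acid. They also leave open whether the effect of thiophen-2-yl in place of thiophen-3-yl holds when the amide-type nitrogen carries 2,3-difluorophenyl or 2,4-difluorophenyl rather than pyridin-3-yl.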